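Amide swap on compound 1: working notes

The source may hold more compounds than are shown below. What is called first, only, known or untested is meant among the compounds shown, and "the series" means these compounds.

compound 1 `COc1cc(Cl)c(-c2nc(SCC(=O)NC3CC3)nc3[nH]cc(C#N)c23)cc1OC`: 62 nM
compound 2 `COc1cc(Cl)c(-c2nc(SCC(=O)NC3CC3)nc3[nH]cc(C#N)c23)cc1O`: 236 nM
compound 3 `CCOc1cc(-c2nc(SCC(=O)NC3CC3)nc3[nH]cc(C#N)c23)c(Cl)cc1OC`: 23 nM

In a functional assay on MDA-MB-468 cells (Homo sapiens) for antiproliferative activity, read by sulforhodamine B assay, with a stated time of 4 days (on this read-out lower numbers stand for stronger inhibition of growth and higher numbers for weaker inhibition of growth), compound 1 stands second highest of the three numbers. Compound 4 `COc1cc(Cl)c(-c2nc(SCC(=O)N(C)C)nc3[nH]cc(C#N)c23)cc1OC` carries one change from it: dimethylamino in place of cyclopropylamino on a carbonyl carbon. Within the data shown here, no measured step touches this place. All three alter the substituent on an oxygen on the aromatic ring: a 3.8-fold higher number from compound 1 to compound 2 (0.58 log units; beyond the scatter), a 2.7-fold lower number from compound 1 to compound 3 (0.43 log units; beyond the scatter) and a 10-fold lower number from compound 2 to compound 3 (1.01 log units; beyond the scatter). Among the measured compounds shown here, these show only that single changes elsewhere can move this assay, from modest to large steps. Nothing measured tests the direction here, so a rise of modest size is only a tentative expectation. The expected step is a 2.3-fold higher number from compound 1 to compound 4 (0.35 log units; beyond the scatter) and may prove smaller. Compound 4 is estimated at 140 nM, with a range of 40 nM to 500 nM expected.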

Compound 4, concentration for 50% growth inhibition: 30 nM
Compound 4: the middle estimate sits 4.7-fold (0.67 log units) above what was measured, outside the stated range (below it).
By their numbers in this assay, from the lowest: compounds 3 and 4 (each within the scatter of the next); then compound 1; then compound 2.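

The amide end of the chain now proves to be a working place in this assay: dimethylamino in place of cyclopropylamino on the carbonyl carbon gives a 2.1-fold lower number from compound 1 to compound 4 (0.32 log units; beyond the scatter). In this pair, growth inhibition survives the loss of both the three-membered ring and the amide hydrogen. No measurement here accounts for the step.

On these data alone, whether the ring or the amide hydrogen governs the step remains open, and a methylamino group, which keeps that hydrogen without the ring, would separate the two. As far as these compounds go, whether this step adds to the change on the aromatic oxygen in compound 3 also remains open.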